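Thioether series: pyridyl to fluorophenyl swap

This account rests on a few compounds, and the source may have more. Where it says the series, first, only, none or still open, it means among the compounds named here.

Compound 2 `CC(Sc1nc2c(cnn2C)c(=O)n1-c1ccccc1)c1ccccn1` stands lowest of the three measured numbers: in an assay on isolated protein for inhibition of aldehyde dehydrogenase 1A1 (Homo sapiens) (a lower number here means a stronger inhibitor, a higher number a weaker inhibitor), compound 2 gives 242 nM against compound 3 `Cn1ncc2c(=O)n(-c3ccccc3)c(CCc3cccc(F)c3)nc21` with 1000 nM and compound 1 `Cn1ncc2c(=O)n(-c3ccccc3)c(COc3cccc(F)c3)nc21` with 8200 nM in the same assay. Compound 4 `CC(Sc1nc2c(cnn2C)c(=O)n1-c1ccccc1)c1cccc(F)c1` differs from compound 2 in one place: 3-fluorophenyl in place of pyridin-2-yl on a saturated chain carbon bound to a saturated chain carbon and a sulfur. Among the measured compounds shown here, the only measured single-point step, an 8.2-fold lower number from compound 1 to compound 3 (0.91 log units; beyond the scatter), concerns a chain atom attached to the core and not an aromatic ring swap, so no measured step bears directly on this change. Without precedent in the series, a step of modest size toward weaker inhibition is expected, a 1.9-fold higher number from compound 2 to compound 4 (0.27 log units; within the scatter). Compound 4 is therefore estimated at 450 nM, with a range from 130 nM to 1600 nM.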

Compound 4, half-maximal inhibitory concentration: 151 nM
For compound 4 the middle estimate is 3.0-fold (0.47 log units) above the measured one, and the stated range covers the measured number.
By their numbers in this assay, from the lowest: compounds 4 and 2 (each within the scatter of the next); then compound 3; then compound 1.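

Notes on the sulfur-bound carbon: in this assay, 3-fluorophenyl in place of pyridin-2-yl gives a 1.6-fold lower number from compound 2 to compound 4 (0.20 log units; within the scatter), so the two compounds cannot be separated. At this place on a saturated chain carbon, the ring nitrogen and its hydrogen-bond acceptor are therefore not required for a number in this range. Nothing available accounts for this result.

Still open, from the compounds shown here alone, is whether the fluorine matters, as plain phenyl would show. Going by these compounds, an amine, a carboxylic acid or a longer chain at this carbon also remains untested here.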